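A few compounds are considered here, and "the series" means these few. Any claim that something is new, unique, unknown or untested is made for them only; others in the source may bear on it.

Compound 1 `C#CCNCc1cn(-c2cc(NC(=S)NCC)ncn2)cn1`: 5240 nM; compound 2 `C#CCN(Cc1cn(-c2cc(NC(=S)NCC)ncn2)cn1)C(C)=O`: > 50000 nM (a limit) ; compound 3 `C#CCN(CC#N)Cc1cn(-c2cc(NC(=S)NCC)ncn2)cn1`: > 50000 nM (a limit).

In an assay on isolated protein for inhibition of Amine oxidase [flavin-containing] B (Homo sapiens), read by fluorescence and Amplex Red, with a stated time of 15 min (a lower number here means a stronger inhibitor, a higher number a weaker inhibitor), compound 1 gives 5240 nM. For compound 3 only the limit > 50000 nM is known, so no number is fixed for it. Two of the three values sit at the limit of > 50000 nM in this assay, at which 2 of the 3 values shown sit. Compound 4 `C#CCN1CCN(Cc2cn(-c3cc(NC(=S)NCC)ncn3)cn2)CC1` differs from compound 3 by a group of 9 heavy atoms (7 carbon, 2 nitrogen; one six-membered non-aromatic ring with 2 hetero atoms) in place of a group of 7 heavy atoms (5 carbon, 2 nitrogen; no ring), on a saturated chain carbon bound to an aromatic carbon. Within the data shown here, the steps that bear on this change both alter the amine nitrogen of compound 1 and both weakened inhibition: an at least 9.5-fold higher number from compound 1 to compound 2 (0.97 log units; beyond the scatter) and an at least 9.5-fold higher number from compound 1 to compound 3 (0.97 log units; beyond the scatter). Compound 4 again carries a substituted amine nitrogen, so in this assay a return to the number of compound 1 is not expected, though some improvement from the limit seems possible. The estimate for compound 4 is 20000 nM, between 5000 nM and 80000 nM. This expected step is an at least 2.5-fold lower number from compound 3 to compound 4 (0.39 log units; beyond the scatter).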

Compound 4, half-maximal inhibitory concentration: > 50000 nM
Compound 4: no number, only a limit (the forecaster's own chance of this, stated with the estimate: 45%); middle value at least 2.5-fold (0.39 log units) from the limit.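

Replacing propargylamino with 4-propargylpiperazin-1-yl in this assay gives an at least 9.5-fold higher number from compound 1 to compound 4 (0.97 log units; beyond the scatter). Even with this amine nitrogen held in a ring, inhibition does not return, and among the compounds shown only compound 1 keeps a hydrogen on that nitrogen. Compound 4 gives only a limit, so the steps linking it to compound 2 and compound 3 cannot be read: the limit of > 50000 nM in this assay, at which 3 of the 4 values shown sit.

On these data alone, how far these three compounds lie apart remains unknown. As far as these compounds go, it also remains open whether a single methyl on that nitrogen, or a morpholine ring in place of the piperazine, would keep any inhibition.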